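The source may hold more compounds than are shown below. What is called first, only, known or untested is meant among the compounds shown, and "the series" means these compounds.

Among the compounds with values here, compound 2 `O=C(c1nc2cc(C(F)(F)F)ccc2s1)N1CCN(c2ccncc2)CC1` is one of two compounds measured in an ADME assay on RAW264.7 cells (Mus musculus) for cytotoxicity, read by MTT assay, with a stated time of 72 h, tested at 50 ug/mL; a higher number here means more inhibition at the concentration tested (going by the name of the read-out), a lower number less inhibition; compound 2 gives 17.5%. The other, compound 1 `COc1ccc(N2CCN(C(=O)c3nc4cc(C(F)(F)F)ccc4s3)CC2)cc1`, differs from it only in the group on the ring nitrogen, and compound 1 gives 19.4%. The step of a number 1.9 percentage points lower from compound 1 to compound 2 (within the scatter) lies within the usual scatter of this assay, so the two numbers cannot be set one above the other, and both show only weak inhibition at the tested concentration.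

Compound 3 `CC(=O)N1CCN(C(=O)c2nc3cc(C(F)(F)F)ccc3s2)CC1` is not yet measured. It differs from compound 2 as follows: acetyl in place of pyridin-4-yl on an amine nitrogen in a ring. Within the data shown here, the only measured step, from compound 1 to compound 2, also changed the group on that same ring nitrogen, swapping one six-membered aromatic ring for another, and it moved the read-out by nothing beyond the scatter. Among the measured compounds shown here, replacing the ring with a small acetyl group is a larger change in kind, and no measured pair covers it, so the expectation rests on the one step alone.

On that basis compound 3 is expected to stay near compound 2, with an estimated step of a number 1.5 percentage points lower from compound 2 to compound 3 (within the scatter) in this assay, and an estimated value of 16%, between 4% and 30%.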

Compound 3, a percentage reported as inhibition, at one concentration (the size of the read-out at that concentration, not a potency): 20.2%
Compound 3: middle estimate off by 4.2 percentage points, on the low side; the measured number falls inside the stated range.
By their numbers in this assay, from the lowest: compounds 2, 1 and 3 (each within the scatter of the next).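

In this assay putting acetyl in place of pyridin-4-yl on the amine nitrogen in a ring gives a number 2.7 percentage points higher from compound 2 to compound 3 (within the scatter) and putting acetyl in place of 4-methoxyphenyl gives a number 0.8 percentage points higher from compound 1 to compound 3 (within the scatter) so neither step can be read as a real change. The earlier pair carried only six-membered aromatic rings on this nitrogen, whereas acetyl has no ring and fewer heavy atoms, so these three compounds show that, at the one concentration tested, the read-out does not separate a ring from a small group without one at this position. Nothing available explains why the three numbers stay so close.

On these data alone, whether this holds for quite different groups on the same nitrogen, such as a longer acyl chain, a primary amine or a carboxylic acid, remains open. As far as these compounds go, each compound is also read at a single concentration, so how the three would compare at other concentrations remains open too.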